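One Methyl Removed on Two Different Cores

A few compounds are considered here, and "the series" means these few. Any claim that something is new, unique, unknown or untested is made for them only; others in the source may bear on it.

Four compounds are compared in an ADME assay on H1-HeLa cells (Homo sapiens) for cytotoxicity, read by MTT assay, with a stated time of 3 days; on this read-out higher numbers stand for lower toxicity in this test and lower numbers for higher toxicity in this test. Compound 1 `CNC(=O)c1cc(Oc2ccc3c(C)c(C(=O)OC)sc3c2)ccn1` gives 10800 nM. Compound 2 `CNC(=O)c1cc(Oc2ccc3c(C)c(C(=O)O)sc3c2)ccn1` differs from compound 1 by hydrogen in place of methyl on an oxygen next to a carbonyl group. In this assay compound 2 reaches only a limit of the test, > 100000 nM, and not a number. The step between them is an at least 9.2-fold higher number from compound 1 to compound 2 (0.96 log units; beyond the scatter).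

Compound 3 `CCOC(=O)c1sc2cc(OC)ccc2c1C` is built on another core, and the difference between the two cores is not broken down here. In this assay compound 3 also sits at a limit rather than at a number, > 100000 nM. Compound 4 `CCOC(=O)c1sc2cc(O)ccc2c1C` has not been measured; it differs from compound 3 by hydrogen in place of methyl on an oxygen on an aromatic ring. Among the compounds with values here, this is the same kind of change as the one from compound 1 to compound 2, but not the same one: there the oxygen stands next to a carbonyl group with a carbonyl carbon as its other neighbour, here it stands on an aromatic ring with an aromatic carbon as its other neighbour.

The expectation for compound 4 rests on compound 3, whose result is a limit, and on (the limit of > 100000 nM in this assay, at which 2 of the 3 values shown sit). The step that is expected is a number no higher from compound 3 to compound 4 (the limit leaves the size open). For compound 4 the estimate in this assay is 100000 nM, with a range expected from 40000 nM to 300000 nM, and a limit rather than a number is the more likely outcome.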

Compound 4, half-maximal cytotoxic concentration: 82000 nM
Beside the measured number, compound 4's estimate is 1.2-fold (0.09 log units) above it; the range from low to high includes it.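

In this assay the swap of methyl for hydrogen on an oxygen does not carry over as one fixed effect from one core to the other: the same change on two cores in this assay, an at least 9.2-fold higher number (0.96 log units; beyond the scatter) from compound 1 to compound 2 and an at least 1.2-fold lower number (0.08 log units; that floor lies within the scatter) from compound 3 to compound 4, at least 11-fold (1.05 log units) apart, beyond the scatter of two such steps. Read alone, the new step is an at least 1.2-fold lower number from compound 3 to compound 4 (0.08 log units; that floor lies within the scatter), and only that floor can be stated, since the starting point of this step is a limit of the test and not a number: the limit of > 100000 nM in this assay, at which 2 of the 4 values shown sit. What this does not show is why the two steps part, since the oxygen stands next to a carbonyl group in one case and on an aromatic ring in the other while the cores differ as well, so the place of the oxygen and the core cannot be told apart, and one pair on each core gives no rule for the whole series.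

The compounds shown leave open how an amine in place of the hydroxy of compound 4 would read in this assay, and whether a longer chain such as ethoxy would read like the methoxy or the hydroxy. They also leave open whether a carboxylic acid in place of the ester on the core of compound 3 would follow the step seen on the core of compound 1.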